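A few compounds are considered here, and "the series" means these few. Any claim that something is new, unique, unknown or untested is made for them only; others in the source may bear on it.

Measured compounds:
- compound 1 `Cc1n[nH]c2ccc(-c3nc4cnc(N5CCN(C)CC5)cn4c3Nc3cccc(Cl)c3)cc12`: "not determined" (no result reported) in a functional assay on MV4-11 cells (Homo sapiens) for inhibition, with a stated time of 120 h; a higher number here means a weaker inhibitor, a lower number a stronger inhibitor
- compound 2 `Cc1n[nH]c2ccc(-c3nc4cnc(N5CCN(C)CC5)cn4c3Nc3ccc(Br)cc3Cl)cc12`: 9220 nM

Working notes on the series. The shared core carries an anilino group on a nitrogen of the core, and the two measured compounds differ only in what that phenyl ring bears. In this assay compound 2 gives 9220 nM, a weak result. Going by the values given here, compound 1, with its 3-chlorophenyl, has no number in this assay at all, so nothing can be said of where it stands relative to compound 2 and no step between them can be stated.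

Compound 3 `Cc1n[nH]c2ccc(-c3nc4cnc(N5CCN(C)CC5)cn4c3Nc3ccc(F)cc3Br)cc12` is not yet measured. It differs from compound 1 by 2-bromo-4-fluorophenyl in place of 3-chlorophenyl on a nitrogen on an aromatic ring. The change swaps one halogenated phenyl for another, keeping the same hydrogen-bond donor and acceptor count. Among the compounds with values here, with no value for compound 1, the size and direction of the step in this assay cannot be anchored; the only guide is compound 2, whose 2-bromo-4-fluorophenyl counterpart resembles the dihalophenyl of compound 3 more closely than the 3-chlorophenyl does. On that basis compound 3 is expected to fall close to compound 2, a weak inhibitor, with wide uncertainty in either direction and a real chance that only a limit is returned.

Estimated for compound 3 in this assay: 8000 nM, range 2500 nM to 25000 nM.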

Compound 3, half-maximal inhibitory concentration: 3830 nM
Estimate against measurement, compound 3: 2.1-fold (0.32 log units) above; the measured number falls inside the stated range.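

In this assay, going by these compounds alone, the swap of 4-bromo-2-chlorophenyl for 2-bromo-4-fluorophenyl on a nitrogen on an aromatic ring gives a 2.4-fold lower number from compound 2 to compound 3 (0.38 log units; beyond the scatter) as the first readable step at this position, so the read-out does respond to which halogens the phenyl carries, although the change is modest and compound 3 at 3830 nM is still a weak inhibitor. Going by these compounds, the step from compound 1 to compound 3 cannot be read, as compound 1 has no result, and the place of 3-chlorophenyl in this trend remains unknown. Nothing measured here accounts for the difference between compound 2 and compound 3.

Both halogens differ together between these two compounds, so the shift cannot be assigned to either one alone, and a compound changing only one of them would be needed to separate them. Also open, on these data alone, is whether the number moves much further with a non-halogen group in this place, such as an unsubstituted phenyl, a phenyl bearing a methoxy group or a carboxylic acid, or a saturated cyclohexyl ring.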